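Compound 1 to compound 4: fluoro to bromo

The compounds below may be only part of what the source reports. "The series", "measured", "known", "first", "only" and "open" are said of these compounds alone.

Measured so far:
- compound 1 `O=S(=O)(Nc1cccc2cccnc12)c1ccc(F)cc1` gives "not determined" (no result reported)
- compound 2 `O=S(=O)(Nc1cccc2cccnc12)c1cnc(Cl)c(Br)c1` gives 67400 nM
- compound 3 `O=S(=O)(Nc1cccc2cccnc12)c1cc(F)cc(F)c1` gives 66300 nM

In an ADME assay on Vero cells (Homo sapiens) for cytotoxicity against Vero (Chlorocebus sabaeus), read by MTT assay (a higher number here means that more compound is tolerated, a lower number that less compound is tolerated), compound 1 stands at "not determined" (no result reported) and so offers no number to start from. Within the data shown here, compound 2 at 67400 nM and compound 3 at 66300 nM lie within the scatter of each other, and these are the only numbers.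

Compound 4 `O=S(=O)(Nc1cccc2cccnc12)c1ccc(Br)cc1` remains to be measured. The step is bromo in place of fluoro on an aromatic carbon and reads as bromo in place of fluoro on an aromatic carbon, para to a large group. Among the measured compounds shown here, no measured pair in this assay shows what this exchange does, so its size cannot be read from the data. No step beyond the scatter is expected in either direction, an expectation resting only on compound 2 with 67400 nM and compound 3 with 66300 nM as anchors. For compound 4 the expected value is 60000 nM with an estimated range of 25000 nM to 120000 nM as a deliberately wide band.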

Compound 4, half-maximal cytotoxic concentration: 88700 nM
For compound 4 the middle estimate is 1.5-fold (0.17 log units) below the measured one, within the range that was stated.
By their numbers in this assay, from the lowest: compounds 3, 2 and 4 (each within the scatter of the next).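

No new step can be read from compound 4, since its one-place partner, compound 1, offers no number for comparison. In this assay the compounds shown leave open what the exchange of fluoro for bromo does. No evidence bears on this result.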